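This account rests on a few compounds, and the source may have more. Where it says the series, first, only, none or still open, it means among the compounds named here.

Compound 1 `CSCC[C@H](NC(=O)c1ccc(CN(Cc2ccccc2)c2cccnc2)cc1-c1ccccc1C)C(=O)O`: 0.83 h
Compound 2 `CSCC[C@H](NC(=O)c1ccc(CN(CC2CCCCC2)c2cccnc2)cc1-c1ccccc1C)C(=O)O`: < 0.4 h, a limit of the assay
Compound 3 `CSCC[C@H](NC(=O)c1ccc(CN(Cc2cc(F)cc(F)c2)c2ccccc2)cc1-c1ccccc1C)C(=O)O`: 1.9 h

In an ADME assay on the whole organism for metabolic stability, with Rattus norvegicus as the target (a lower number here means that the compound disappears faster, a higher number that the compound lasts longer), compound 3 holds the highest number, 1.9 h, and compound 1 lies lower at 0.83 h. Within the data shown here, the one measured step, an at least 2.0-fold lower number from compound 1 to compound 2 (0.31 log units; beyond the scatter), concerns a different change and ends at the limit of < 0.4 h in this assay, at which 1 of the 3 values shown sits.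

Compound 4 `CSCC[C@H](NC(=O)c1ccc(CN(Cc2cc(F)cc(F)c2)c2cccnc2)cc1-c1ccccc1C)C(=O)O` carries pyridin-3-yl in place of phenyl on an amine nitrogen. Among the measured compounds shown here, no measured step tests this swap, so no change beyond the scatter is expected. Compound 1, which also carries pyridin-3-yl, gives 0.83 h, which tilts the expectation slightly downward. The expected step is a 1.4-fold lower number from compound 3 to compound 4 (0.13 log units; within the scatter). For compound 4 the estimated half-life is 1.4 h, with an expected range from 0.7 h to 2.8 h.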

Compound 4, half-life: 1 h
Estimate against measurement, compound 4: 1.4-fold (0.15 log units) above; measured number inside the range.
By their numbers in this assay, from the lowest: compounds 1, 4 and 3 (each within the scatter of the next, the first and the last beyond it). At a limit, below all of these: compound 2.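

In this assay, pyridin-3-yl in place of phenyl on an amine nitrogen gives a 1.9-fold lower number from compound 3 to compound 4 (0.28 log units; within the scatter), so the swap stays within the scatter. With pyridin-3-yl held, 3,5-difluorophenyl in place of phenyl gives a 1.2-fold higher number from compound 1 to compound 4 (0.08 log units; within the scatter), while 3,5-difluorophenyl in place of cyclohexyl gives an at least 2.5-fold higher number from compound 2 to compound 4 (0.39 log units; beyond the scatter). That last step starts from compound 2, which stands at a limit and not at a number: the limit of < 0.4 h in this assay, at which 1 of the 4 values shown sits.

Open, from the compounds shown here alone, is how a pyrimidin-5-yl or pyridin-4-yl ring on the amine nitrogen would read. Also open, going by these compounds, is whether an open chain such as butyl, in place of 3,5-difluorophenyl, would fall as cyclohexyl does.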